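The source may report more compounds than this note shows. Statements on the series, on what has been measured and on what is new or still open speak of the compounds shown alone.

Working notes on a small set of hydrazinyl benzothiazoles. Compound 1 `Cc1cccc2sc(NN)nc12` and compound 2 `NNc1nc2c([N+](=O)[O-])cccc2s1` carry only the bare hydrazine on the core; compound 3 `Cc1cccc2sc(Nn3c(-c4ccc([N+](=O)[O-])cc4)nnc3-c3cccnc3)nc12` and compound 4 `O=[N+]([O-])c1ccc(-c2nnc(-c3cccnc3)n2Nc2nc3c([N+](=O)[O-])cccc3s2)cc1` carry the same two cores with a substituted triazole on the hydrazine nitrogen. How the core of compound 1 and the core of compound 3 differ is not broken down here.

In an ADME assay on MT4 cells (Homo sapiens) for cytotoxicity, read by MTT assay, with a stated time of 5 days (a higher number here means that more compound is tolerated, a lower number that less compound is tolerated), compound 1 gives 9.8 ug/mL. Compound 2 gives 14.5 ug/mL in this assay. Compound 3 gives 13.5 ug/mL in this assay, so that the three numbers sit close together and no order among them can be read.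

Going by the values given here, the step nitro in place of methyl on an aromatic carbon is the one measured change in the set; it produced a 1.5-fold higher number from compound 1 to compound 2 (0.17 log units; within the scatter). The same change, (nitro in place of methyl on an aromatic carbon), with its place described in the same words, leads from compound 3 to compound 4 and has not yet been measured.

Given that the only measured instance of this change, from compound 1 to compound 2, stayed within the scatter, the step from compound 3 to compound 4 in this assay is expected to be a 1.2-fold higher number from compound 3 to compound 4 (0.07 log units; within the scatter), a shift too small to count as a change. For compound 4 the expected value in this assay is 16 ug/mL, with a likely range from 9 ug/mL to 28 ug/mL. This estimate rests solely on the value that compound 3 gives, 13.5 ug/mL, and on the step of a 1.5-fold higher number from compound 1 to compound 2 (0.17 log units; within the scatter).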

Compound 4, half-maximal cytotoxic concentration: 13.8 ug/mL
For compound 4 the middle estimate is 1.2-fold (0.06 log units) above the measured one; low and high end bracket the measured number.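

In this assay, nitro in place of methyl on an aromatic carbon of the core carrying the substituted triazole gives a 1.0-fold higher number from compound 3 to compound 4 (0.01 log units; within the scatter), so on this core, as on the core with the bare hydrazine, the change has no effect that can be told from the scatter. Set side by side, the two steps do not differ: the same change on two cores in this assay, a 1.5-fold higher number (0.17 log units; within the scatter) from compound 1 to compound 2 and a 1.0-fold higher number (0.01 log units; within the scatter) from compound 3 to compound 4, 1.4-fold (0.16 log units) apart, within the scatter of two such steps

Going by these compounds alone, this shows that, in this one read-out, the absence of a readable shift carries over from one core to the other; it does not show that methyl and nitro are interchangeable in general, and with only two steps, neither beyond the scatter, the pair cannot test whether a real shift would carry over between cores.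

The compounds shown leave open whether other groups on the same aromatic carbon, such as an amine, a carboxylic acid or a longer chain, would also leave the number in this assay within the scatter on both cores. They also leave open whether the change would behave the same way with other substituents on the triazole, for example an amine in place of the nitro on its outer ring.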